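From bromo to iodo on a shared core

The source may hold more compounds than are shown below. What is called first, only, known or untested is meant among the compounds shown, and "the series" means these compounds.

Compound 1 (`O=C(CCCCCC(=O)NCc1ccc2cc(Cl)ccc2n1)NO`) gives 9130 nM
Compound 2 (`O=C(CCCCCC(=O)NCc1ccc2cc(Br)ccc2n1)NO`) gives 9260 nM

Among the compounds with values here, both values come from a functional assay on PC-3 cells (Homo sapiens) for inhibition, read by MTT assay, with a stated time of 48 h (on this read-out higher numbers stand for weaker inhibition and lower numbers for stronger inhibition), where compound 2 stands level with compound 1, its only measured neighbour (a 1.0-fold higher number from compound 1 to compound 2 (0.01 log units; within the scatter)). The two numbers cannot be told apart, so neither compound can be ranked above the other.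

The next compound, compound 3 (`O=C(CCCCCC(=O)NCc1ccc2cc(I)ccc2n1)NO`), keeps the shared core of compound 2 and changes a single group (iodo in place of bromo on an aromatic carbon). This is iodo in place of bromo on an aromatic carbon of a six-membered aromatic ring of carbon only.

Within the data shown here, only one measured step bears on this change, the exchange of chloro for bromo in compound 2, and it stayed within the scatter (a 1.0-fold higher number from compound 1 to compound 2 (0.01 log units; within the scatter)). One small step is slender evidence, but it gives no reason to expect a shift in either direction in this assay. No step beyond the scatter is therefore expected, and the estimated change is correspondingly small (a 1.0-fold lower number from compound 2 to compound 3 (0.01 log units; within the scatter)). Compound 3 is estimated at 9000 nM (expected range 5000 nM to 16000 nM).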

Compound 3, half-maximal inhibitory concentration: 8480 nM
For compound 3 the middle estimate is 1.1-fold (0.03 log units) above the measured one, within the range that was stated.
By their numbers in this assay, from the lowest: compounds 3, 1 and 2 (each within the scatter of the next).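

In this assay the exchange of bromo for iodo on this aromatic carbon gives a 1.1-fold lower number from compound 2 to compound 3 (0.04 log units; within the scatter) and the wider exchange of chloro for iodo gives a 1.1-fold lower number from compound 1 to compound 3 (0.03 log units; within the scatter) so both steps stay within the scatter. The earlier pair showed a single exchange at this place, meta to a fused ring and para to a fused ring, whereas chloro, bromo and iodo can now be compared, and this read-out does not separate any of the three. Nothing measured here explains why the numbers stay so close together.

As far as these compounds go, all three compounds carry a single halogen atom at this place, so it remains open whether fluoro, plain hydrogen, or a group of another kind, such as an amine, a methoxy group or a carboxylic acid, would give a number beyond the scatter. The compounds shown also share one chain between the amide and the hydroxamic acid, which leaves open whether a shorter or longer chain would change the number, and whether the halogens would remain indistinguishable on such a chain.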